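A few compounds are considered here, and "the series" means these few. Any claim that something is new, unique, unknown or untested is made for them only; others in the source may bear on it.

Measured compounds:

- compound 1, `C[C@H](C#Cc1cccc(C(=O)NCc2ccccc2C(F)(F)F)c1)N(O)C(N)=O`: 600 nM
- compound 2, `CC(C#Cc1ccc(C(=O)NCc2ccccc2C(F)(F)F)o1)N(O)C(N)=O`: 4000 nM
- compound 3, `C[C@H](C#Cc1cccc(C(=O)NCC[C@H](c2ccc(F)cc2)c2ccc(C(F)(F)F)cc2)c1)N(O)C(N)=O`: 230 nM

In an assay for inhibition of Polyunsaturated fatty acid 5-lipoxygenase (Homo sapiens), read by HPLC, with stated times of 15 min and 10 min (on this read-out higher numbers stand for weaker inhibition and lower numbers for stronger inhibition), compound 1 stands second highest of the three numbers. Compound 3 gives the nearest number, 230 nM, a gap beyond the scatter, and compound 2 gives the furthest, 4000 nM, also beyond the scatter. For the measured compounds named here, no single-point step between measured compounds is available in this set.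

The next compound, compound 4, is `C[C@@H](C#Cc1cccc(C(=O)NCc2ccccc2C(F)(F)F)c1)N(O)C(N)=O`. Against compound 1 it shows (the two compounds have the same atoms and bonds and differ only in configuration as drawn: 1 of 1 stereo elements differ; a stereocentre at a saturated chain carbon is drawn R in compound 1 and S in compound 4). No pair in the measured set isolates a change of this kind, so there is no shown step to lean on.

For a change of configuration alone, the outcome is expected to range from no step beyond the scatter to a clear loss in this assay, and the expected number for compound 4 lies toward a weaker reading than compound 1, with the step from a 2.2-fold higher number from compound 1 to compound 4 (0.34 log units; beyond the scatter) taken as the estimate. Compound 4 is estimated at 1300 nM, with a range from 350 nM to 5000 nM reflecting that this direction is not anchored by any measured pair here.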

Compound 4, half-maximal inhibitory concentration: 700 nM
Estimate against measurement, compound 4: 1.9-fold (0.27 log units) above; the range from low to high includes it.
By their numbers in this assay, from the lowest: compound 3; then compounds 1 and 4 (each within the scatter of the next); then compound 2.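

The earlier compounds offered no pair that isolated the saturated chain carbon, and compounds 1 and 4 now provide one, with nothing else in the structure altered: the fact that compounds 1 and 4 differ only in the configuration as drawn

In this assay, inverting this stereocentre from R to S gives a 1.2-fold higher number from compound 1 to compound 4 (0.07 log units; within the scatter), so the two drawn configurations cannot be told apart on this read-out for the core of compound 1. Within this pair, configuration at the chain carbon therefore shows no measurable bearing on inhibition, and the wider gaps seen earlier among compounds 1, 2 and 3 cannot be assigned to this stereocentre, since those compounds differ from each other in more than one place.

From the compounds shown here alone, whether the same holds with the larger amide substituent of compound 3, or on the furan-containing core of compound 2, which is drawn without configuration at this carbon, remains open. Also open, going by these compounds, is whether the result would survive a change at the stereocentre itself, such as an ethyl group in place of the methyl, where a difference between the two configurations might or might not appear in this assay.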